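The source may report more compounds than this note shows. Statements on the series, on what has been measured and on what is new or still open speak of the compounds shown alone.

In a functional assay on MCF7 cells (Homo sapiens) for antiproliferative activity, read by CellTiter-Glo, with a stated time of 5 days (a lower number here means a stronger inhibitor, a higher number a weaker inhibitor), compound 1 (`O=C(O)/C=C/c1ccc(/C(=C(\c2ccccc2)C2CCC2)c2ccc(-c3cncs3)cc2)cc1`) gives 9.2 nM and compound 2 (`O=C(O)/C=C/c1ccc(/C(=C(\c2ccccc2)C2CCC2)c2ccc(-c3cn[nH]c3)cc2)cc1`) gives 11 nM and the two stand level within the scatter (a 1.2-fold higher number from compound 1 to compound 2 (0.08 log units; within the scatter)). Compound 3 (`O=C(O)/C=C/c1ccc(/C(=C(\c2ccc(C(F)(F)F)cc2Cl)C2CCC2)c2ccc(-c3cn[nH]c3)cc2)cc1`) differs from compound 2 in one group (2-chloro-4-(trifluoromethyl)phenyl in place of phenyl on a double-bonded chain carbon bound to a double-bonded chain carbon and a saturated ring carbon). For the measured compounds named here, the only measured step lies elsewhere on the shared core, so it offers no direct guide, and both measured compounds carry plain phenyl at this place. The expected step in this assay is estimated as a 1.8-fold lower number from compound 2 to compound 3 (0.26 log units; within the scatter) with wide uncertainty. Compound 3 is estimated at 6 nM (range 1.5 nM to 25 nM).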

Compound 3, half-maximal inhibitory concentration: 16 nM
Compound 3: middle estimate off by 2.7-fold (0.43 log units), on the low side; low and high end bracket the measured number.
By their numbers in this assay, from the lowest: compounds 1, 2 and 3 (each within the scatter of the next).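

For the compounds shown here, at the double-bonded chain carbon bound to a double-bonded chain carbon and a saturated ring carbon, compound 3 gives the first reading of a group other than phenyl. In this assay, 2-chloro-4-(trifluoromethyl)phenyl in place of phenyl gives a 1.5-fold higher number from compound 2 to compound 3 (0.16 log units; within the scatter), so the two compounds stand level despite the added chlorine and trifluoromethyl. Nothing shown accounts for this result. The compounds shown leave open how the chlorine and trifluoromethyl each read alone, and whether an amine or a methoxy group on this ring would also keep the number level.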